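Carbonyl to Thiocarbonyl at the Ring Amine

The source may report more compounds than this note shows. Statements on the series, on what has been measured and on what is new or still open speak of the compounds shown alone.

Compound 1, `Cn1nc(COc2ccc(F)c(F)c2)c2c1CCN(C(=O)Nc1ccc(Cl)cc1)C2`, gives 4600 nM in an assay on cells for inhibition of Pendrin (Mus musculus), read by fluorescence, with a stated time of 10 min; a higher number here means a weaker inhibitor, a lower number a stronger inhibitor.
Compound 2, `Cn1nc(COc2cc(F)cc(F)c2)c2c1CCN(C(=O)Nc1ccc(Cl)cc1)C2`, gives 3100 nM in this assay.
Compound 3, `Cn1nc(C(=O)O)c2c1CCN(C(=O)Nc1ccc(Cl)cc1)C2`, gives > 10000 nM in this assay, a limit of the assay rather than a number.

Compound 2 holds the lower of the two numbers shown, and its nearest neighbour is compound 1, a step of a 1.5-fold lower number from compound 1 to compound 2 (0.17 log units; within the scatter). The third value, that of compound 3, is a limit (the limit of > 10000 nM in this assay, at which 1 of the 3 values shown sits).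

Compound 4, `Cn1nc(COc2cc(F)cc(F)c2)c2c1CCN(C(=S)Nc1ccc(Cl)cc1)C2`, differs from compound 2 by a group of 10 heavy atoms (7 carbon, 1 nitrogen, 1 sulfur, 1 chlorine; one six-membered aromatic ring of carbon only) in place of a group of 10 heavy atoms (7 carbon, 1 nitrogen, 1 oxygen, 1 chlorine; one six-membered aromatic ring of carbon only), on an amine nitrogen in a ring. The two measured steps, a 1.5-fold lower number from compound 1 to compound 2 (0.17 log units; within the scatter) and an at least 3.2-fold higher number from compound 2 to compound 3 (0.50 log units; beyond the scatter), both alter the group on an aromatic carbon or the aryl on an oxygen on a saturated carbon, far from the amine nitrogen in the ring. Among the compounds with values here, no measured step touches that nitrogen, so nothing here shows how the swap of oxygen for sulfur in this group acts. With no guidance from the data, the expected step of a 1.3-fold higher number from compound 2 to compound 4 (0.11 log units; within the scatter) is placed within the scatter, with a wide margin in both directions. Compound 4 is therefore expected to give about 4000 nM in this assay, estimated to fall between 1500 nM and 12000 nM.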

Compound 4, half-maximal inhibitory concentration: > 10000 nM
Compound 4: a limit, no number; the forecaster's own chance of this, stated with the estimate: 25%; middle value at least 2.5-fold (0.39 log units) away from the limit.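

Within the data shown here, the replacement of oxygen by sulfur in the carbonyl of the group on the amine nitrogen in the ring gives the first measured step at this place: an at least 3.2-fold higher number from compound 2 to compound 4 (0.50 log units; beyond the scatter). The earlier steps shown here touched only the far end of the molecule, whereas this one shows that this assay also responds to a single-atom change here, even though the leaving and entering groups match in their counts of heavy atoms, double bonds, hydrogen-bond donors and acceptors. The result for compound 4 is a limit rather than a number, so the step gives only a lower bound on the size of the change, and compound 4 joins compound 3 at the same limit: the limit of > 10000 nM in this assay, at which 2 of the 4 values shown sit.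

The compounds shown leave open whether the loss belongs to the thiocarbonyl itself or would follow any replacement of the carbonyl, such as a sulfonyl or a plain methylene, and whether a methyl on the amide hydrogen's nitrogen would be tolerated. They also leave open whether the same exchange would act alike with the 3,4-difluorophenyl group of compound 1, or with a group other than 4-chlorophenyl, such as 4-methoxyphenyl.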